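The compounds below may be only part of what the source reports. "The series", "measured", "known", "first", "only" and "open" are said of these compounds alone.

Compound 1 `Cn1c(CC2(C)CO2)cc(=O)n(C)c1=O`: 4000 nM; compound 2 `Cn1c(CC2(c3ccccc3)CO2)cc(=O)n(C)c1=O`: 3700 nM; compound 3 `Cn1c(C[C@]2(C)CCCO2)cc(=O)n(C)c1=O`: 1380000 nM.

In a functional assay on MDCK cells (Canis lupus familiaris) for inhibition (a higher number here means that more compound is tolerated, a lower number that less compound is tolerated), compound 1 gives 4000 nM and compound 2 gives 3700 nM; the step of a 1.1-fold lower number from compound 1 to compound 2 (0.03 log units; within the scatter) is phenyl in place of methyl on a saturated ring carbon. Compound 3, in this assay, gives 1380000 nM, the highest number of the three; how the core of compound 3 differs from the core of compound 1 is not broken down here. Compound 4 `Cn1c(C[C@]2(c3ccccc3)CCCO2)cc(=O)n(C)c1=O` carries the same kind of change, (phenyl in place of methyl on a saturated ring carbon), on a five-membered rather than a three-membered ring. Because the step of a 1.1-fold lower number from compound 1 to compound 2 (0.03 log units; within the scatter) lay within the scatter, the step of a 1.4-fold lower number from compound 3 to compound 4 (0.14 log units; within the scatter) is expected to be small, so compound 4 is estimated at 1000000 nM in this assay, between 300000 nM and 3000000 nM.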

Compound 4, half-maximal cytotoxic concentration: 547000 nM
The estimate for compound 4 lay 1.8-fold (0.26 log units) above the measured number; measured number inside the range.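

Phenyl in place of methyl on a saturated ring carbon gives a 2.5-fold lower number from compound 3 to compound 4 (0.40 log units; beyond the scatter) in this assay. Set beside the same change on the other core, this step differs from the earlier one by no more than the scatter allows: the same change on two cores in this assay, a 1.1-fold lower number (0.03 log units; within the scatter) from compound 1 to compound 2 and a 2.5-fold lower number (0.40 log units; beyond the scatter) from compound 3 to compound 4, 2.3-fold (0.37 log units) apart, within the scatter of two such steps. Going by these compounds alone, the change therefore carries from the core of compound 1 to the core of compound 3 without a demonstrable difference in size, but two pairs establish no general rule and do not explain why only one step lies beyond the scatter.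

The compounds shown leave open whether an amine, a carboxylic acid or a longer chain on that ring carbon would behave as phenyl does. They also leave open whether the change would carry to any further core.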